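The source may report more compounds than this note shows. Statements on the series, on what has been measured and on what is new or still open speak of the compounds shown alone.

Compound 1 `Cc1nn(CC(=O)N2CCN(c3sc(C(F)(F)F)nc3-c3nc4ccccc4[nH]3)C[C@H]2C)cc1CN(C)C` is the reference point of this account. Going by the values given here, in a functional assay on CHO-K1 cells for antagonist activity at C-X-C chemokine receptor type 3 (Homo sapiens), read by FLIPR, with a stated time of 10 min, in the presence of a further agent that is not named here (a higher number here means a weaker inhibitor, a lower number a stronger inhibitor), compound 1 gives 2.7 nM, the lower of the two numbers measured so far. Among the compounds with values here, the only other measured compound, compound 2 `Cc1nc(C)n(CC(=O)N2CCN(c3sc(C(F)(F)F)nc3-c3nc4ccc(OC5COC5)cc4[nH]3)C[C@H]2C)n1`, differs from compound 1 in more than one place; in this assay compound 2 gives 68 nM, and the gap between the two values lies beyond the usual scatter, so compound 1 stands as the stronger inhibitor of the pair. Within the data shown here, no step between measured compounds that differ in a single place is available, so the size of any one change has not been calibrated here.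

The step of interest leads from compound 1 to compound 3 `C[C@@H]1CN(c2sc(C(F)(F)F)nc2-c2nc3ccccc3[nH]2)CCN1C(=O)Cn1cnc2c1CCN(C)C2`, which has not yet been measured. The change is a group of 10 heavy atoms (7 carbon, 3 nitrogen; one five-membered aromatic ring with 2 hetero atoms, one six-membered non-aromatic ring with 1 hetero atom) in place of a group of 10 heavy atoms (7 carbon, 3 nitrogen; one five-membered aromatic ring with 2 hetero atoms), on a saturated chain carbon bound to a carbonyl carbon. Among the measured compounds shown here, with no measured pair to show what such a change does, the expectation is a step of modest size, most likely toward a somewhat higher number, a 3.0-fold higher number from compound 1 to compound 3 (0.47 log units; beyond the scatter). Compound 3 is accordingly estimated to give 8 nM in this assay, with a range from 2.5 nM to 25 nM.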

Compound 3, half-maximal inhibitory concentration in the C-X-C chemokine receptor type 3 assay: 3.6 nM
Beside the measured number, compound 3's estimate is 2.2-fold (0.35 log units) above it; the measured number falls inside the stated range.
By their numbers in the C-X-C chemokine receptor type 3 assay, from the lowest: compounds 1 and 3 (each within the scatter of the next); then compound 2.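

Going by these compounds alone, in the C-X-C chemokine receptor type 3 assay this is the first single-place step available, and it reads a 1.3-fold higher number from compound 1 to compound 3 (0.12 log units; within the scatter), so on a saturated chain carbon bound to a carbonyl carbon the 4-((dimethylamino)methyl)-3-methyl-1H-pyrazol-1-yl group and the entering group, which adds a six-membered non-aromatic ring with 1 hetero atom, cannot be told apart in this assay. In a physicochemical assay for solubility, in simulated intestinal fluid (on this read-out higher numbers stand for higher solubility and lower numbers for lower solubility), compound 1 gives 645 ug/mL. In the physicochemical assay the step reads an at least 1.4-fold higher number from compound 1 to compound 3 (0.15 log units; that floor lies within the scatter), which says that the exchange gives no sign of a loss on this read-out. In the physicochemical assay compound 3 gives > 920 ug/mL, which is a limit and not a number: the limit of > 920 ug/mL in the physicochemical assay, at which 1 of the 2 values shown sits.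

The compounds shown leave open how far compound 3 truly lies from compound 1 on that read-out, and whether the same exchange gives the same step on a core carrying a different substituent. They also leave open how this place would respond in either assay to a group without a ring nitrogen, such as a carboxylic acid or a simple ether chain.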